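Triazine herbicides: swapping a secondary amine for dipropylamino

The source may report more compounds than this note shows. Statements on the series, on what has been measured and on what is new or still open speak of the compounds shown alone.

Measured compounds:
- compound 1, `CC[C@@H](C)Nc1nc(Cl)nc(N[C@@H](C)c2ccccc2)n1`: 7410 nM
- compound 2, `CCNc1nc(Cl)nc(NC(C)c2ccccc2)n1`: 9770 nM

Of the compounds shown here, two share a core and have been tested in an ADME assay on the whole organism for inhibition, with Echinochloa crus-galli var. formosensis as the target, with a stated time of 4 days; a higher number here means a weaker inhibitor, a lower number a stronger inhibitor. Compound 1 gives 7410 nM, the lowest of the two numbers. Compound 2 gives 9770 nM, which is within the scatter of compound 1, so the two cannot be told apart on these numbers.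

Compound 3, `CCCN(CCC)c1nc(Cl)nc(N[C@@H](C)c2ccccc2)n1`, has not yet been measured in this assay. It differs from compound 1 in one place: dipropylamino in place of (sec-butyl)amino on an aromatic carbon. The group that leaves carries a hydrogen-bond donor and a defined stereocentre; the group that enters carries neither and is two heavy atoms larger. Going by the values given here, no step between measured compounds shows what such a change does here, so the expectation rests on the closeness of compound 1 and compound 2 alone.

For compound 3 the expected step is a 2.0-fold higher number from compound 1 to compound 3 (0.31 log units; beyond the scatter), a modest weakening that may not clear the scatter. Compound 3 is therefore estimated at 15000 nM, with a range from 5000 nM to 50000 nM.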

Compound 3, half-maximal inhibitory concentration: 100 nM
Beside the measured number, compound 3's estimate is 150-fold (2.18 log units) above it; measured number below the stated range.
By their numbers in this assay, from the lowest: compound 3; then compounds 1 and 2 (each within the scatter of the next).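

In this assay, this place on the shared core, on an aromatic carbon between two ring nitrogen atoms, proves far from indifferent to the group it carries: dipropylamino in place of (sec-butyl)amino gives a 74-fold lower number from compound 1 to compound 3 (1.87 log units; beyond the scatter), a large step towards a stronger inhibitor. The close values of compound 1 and compound 2 gave no sign that a single change could move the number this far. The change alters several things at once, as the hydrogen-bond donor and the defined stereocentre both leave and the group grows from 5 heavy atoms to 7, and no independent measurement accounts for the size of the step.

On these data alone, what stays open is which part of the change carries the step: the loss of the donor, the loss of the stereocentre or the larger group. Dimethylamino or diethylamino would test shorter chains on a nitrogen with no hydrogen, n-propylamino would test a single propyl chain that keeps the donor, and dipropylamino on the core of compound 2 would show whether the step holds beside a different partner.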